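From 2-chlorophenyl to 4-(dimethylamino)phenyl: an unmeasured step

The source may hold more compounds than are shown below. What is called first, only, known or untested is meant among the compounds shown, and "the series" means these compounds.

Compound 1 `CCCSc1nc(N/N=C/c2ccccc2Cl)c2nnn(Cc3ccccc3)c2n1`: 13800 nM
Compound 2 `CCCSc1nc(N/N=C(\C)c2ccccc2O)c2nnn(Cc3ccc(O)cc3)c2n1`: 9520 nM

In a functional assay on MCF7 cells (Homo sapiens) for antiproliferative activity, read by MTT assay, with a stated time of 72 h (on this read-out lower numbers stand for stronger inhibition and higher numbers for weaker inhibition), compound 1 gives 13800 nM, which lies within the usual scatter of compound 2 at 9520 nM. Within the data shown here, the two numbers therefore set no order between these compounds.

Compound 3 `CCCSc1nc(N/N=C/c2ccc(N(C)C)cc2)c2nnn(Cc3ccccc3)c2n1` has not yet been measured. It carries 4-(dimethylamino)phenyl in place of 2-chlorophenyl on a carbon with a double bond to nitrogen. Among the measured compounds shown here, compound 1 and compound 2 differ in more than one place, so no measured step speaks directly to this change. The data offer no direction for it, and no shift beyond the scatter is expected in this assay. The expected step is a 1.4-fold lower number from compound 1 to compound 3 (0.14 log units; within the scatter). Compound 3 is estimated at 10000 nM, with an expected range of 3500 nM to 30000 nM.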

Compound 3, half-maximal inhibitory concentration: 12200 nM
The estimate for compound 3 lay 1.2-fold (0.09 log units) below the measured number; the measured number falls inside the stated range.
By their numbers in this assay, from the lowest: compounds 2, 3 and 1 (each within the scatter of the next).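

In this assay, among these compounds, the step at this position is a 1.1-fold lower number from compound 1 to compound 3 (0.05 log units; within the scatter), the first change in a single place that can be read. On a carbon with a double bond to nitrogen, 2-chlorophenyl and 4-(dimethylamino)phenyl therefore cannot be told apart by this read-out, although the two groups differ in their atoms and 4-(dimethylamino)phenyl counts a hydrogen-bond acceptor where 2-chlorophenyl counts none. Nothing available explains this result.

Compound 2 differs from compound 1 and compound 3 in more than one place, so its steps cannot be read and it says nothing about this change. From the compounds shown here alone, whether a group such as a carboxylic acid or a primary amine at this same place would shift the number beyond the scatter remains open.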